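One triazole swapped for another on compound 3

The source may hold more compounds than are shown below. What is called first, only, known or untested is meant among the compounds shown, and "the series" means these compounds.

In an ADME assay on NIH3T3 cells (Mus musculus) for cytotoxicity (a higher number here means that more compound is needed for the effect, a lower number that less compound is needed), compound 1 `COc1cccc(Nc2cccc(Cn3ccnc3)c2)c1` gives > 100000 nM, which is a limit of the assay and not a measured number. Two related structures do give numbers: compound 2 `Cc1ccccc1Oc1cccc(Cn2ccnc2)c1` reads 79300 nM and compound 3 `Cc1cc(Oc2cccc(Cn3ccnn3)c2)cc(C)c1Cl` reads 66800 nM. These two values lie within the usual scatter of repeated measurements, so compound 3 stands level with compound 2.

The next structure, compound 4 `Cc1cc(Oc2cccc(Cn3cnnc3)c2)cc(C)c1Cl`, has not yet been measured. It has the same atoms as compound 3, joined differently: 4H-1,2,4-triazol-4-yl in place of 1H-1,2,3-triazol-1-yl on a saturated chain carbon bound to an aromatic carbon. Going by the values given here, no measured pair in this small set differs in one place only, so nothing here shows directly what such a swap does.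

The starting point for an expectation is therefore compound 3 at 66800 nM, since one five-membered aromatic ring simply replaces another of the same atom count. In this assay, no shift beyond the scatter is expected, and the estimate amounts to a 1.1-fold higher number from compound 3 to compound 4 (0.05 log units; within the scatter). Compound 4 is expected at 75000 nM, with an estimated range from 40000 nM to 100000 nM.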

Compound 4, half-maximal effective concentration: > 100000 nM
Compound 4: only a limit was reported; the forecaster's own chance of this, stated with the estimate: 30%; at least 1.3-fold (0.12 log units) between middle value and limit.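

Going by these compounds alone, this is the first pair in the set that differs in one place only, so the change from 1H-1,2,3-triazol-1-yl to 4H-1,2,4-triazol-4-yl on a saturated chain carbon bound to an aromatic carbon can now be read directly in this assay: the pair gives an at least 1.4-fold higher number from compound 3 to compound 4 (0.17 log units; that floor lies within the scatter). Even that floor stays within the scatter, so the pair shows that this swap of one triazole for the other brought no lower number, but not that it clearly raised the number. On these data alone, the result for compound 4 is a limit of the assay and not a number, so the real size of the step stays unknown, because the readings stop there: the limit of > 100000 nM in this assay, at which 2 of the 4 values shown sit.

The compounds shown leave open whether the same swap would behave alike on another core, since only the core shared by compound 3 and compound 4 carries a triazole here. They also leave open what a quite different group in this place, such as an amine or a carboxylic acid on the saturated chain carbon bound to an aromatic carbon, would do to the number.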